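Enaminone series: aryl swap on the amine nitrogen

A few compounds are considered here, and "the series" means these few. Any claim that something is new, unique, unknown or untested is made for them only; others in the source may bear on it.

Measured so far:
compound 1 `COc1cc(N/C=C\C(=O)c2cn(-c3ccccc3)nc2-c2ccc(F)cc2)cc(OC)c1OC` — 9350 nM
compound 2 `COc1cc(-c2nn(-c3ccccc3)cc2C(=O)/C=C\Nc2ccc(F)cc2)cc(OC)c1OC` — 15600 nM

In a functional assay on A549 cells (Homo sapiens) for antiproliferative activity, read by MTT assay, with a stated time of 48 h (on this read-out higher numbers stand for weaker inhibition and lower numbers for stronger inhibition), compound 2 gives 15600 nM, the higher of the two numbers recorded so far. Compound 1 gives 9350 nM in this assay; the two values sit within the scatter of each other, so no order between them is claimed.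

Compound 3 `COc1cc(N/C=C\C(=O)c2cn(-c3ccccc3)nc2-c2cc(OC)c(OC)c(OC)c2)cc(OC)c1OC` differs from compound 2 by 3,4,5-trimethoxyphenyl in place of 4-fluorophenyl on an amine nitrogen. Within the data shown here, no step between measured compounds covers this change, so nothing measured constrains it. The step from compound 2 to compound 3 in this assay is expected to be small, a 1.4-fold lower number from compound 2 to compound 3 (0.15 log units; within the scatter), with no direction beyond the scatter. Compound 3 is therefore expected to give 11000 nM in this assay, within a range of 3000 nM to 40000 nM.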

Compound 3, half-maximal inhibitory concentration: 7980 nM
Beside the measured number, compound 3's estimate is 1.4-fold (0.14 log units) above it; measured number inside the range.
By their numbers in this assay, from the lowest: compounds 3, 1 and 2 (each within the scatter of the next).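

At the amine nitrogen, 3,4,5-trimethoxyphenyl in place of 4-fluorophenyl gives a 2.0-fold lower number from compound 2 to compound 3 (0.29 log units; within the scatter) in this assay, on an aromatic carbon the same swap gives a 1.2-fold lower number from compound 1 to compound 3 (0.07 log units; within the scatter) and both steps lie within the scatter. Neither place therefore separates these two aryl groups on this read-out, even with the hydrogen-bond acceptors that 3,4,5-trimethoxyphenyl brings. Nothing available bears on the reason for this.

On these data alone, whether any aryl group at these places can move the number beyond the scatter remains open. A carboxylic acid or an amine on the aryl group at the amine nitrogen would be a sharper test.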